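The compounds below may be only part of what the source reports. "The series", "measured", "known", "first", "only" and "open" are said of these compounds alone.

Measured in a functional assay on HeLa cells (Homo sapiens) for cytotoxicity, read by MTT assay, with a stated time of 48 h; on this read-out higher numbers stand for an effect only at larger amounts of compound and lower numbers for an effect already at smaller amounts: compound 1 `CSc1ccc(/C=N/n2c(Cc3ccc(S(C)(=O)=O)cc3)n[nH]c2=S)cc1` gives 50000 nM. Compound 2 `CS(=O)(=O)c1ccc(Cc2n[nH]c(=S)n2/N=C/c2cccnc2)cc1` gives > 100000 nM, which is a limit of the assay and not a number. Compound 3 `CS(=O)(=O)c1ccc(Cc2n[nH]c(=S)n2/N=C/c2cccs2)cc1` gives 100000 nM.

Compound 1 holds the lowest of the two numbers shown, with a 2.0-fold higher number from compound 1 to compound 3 (0.30 log units; within the scatter). Compound 4 `CS(=O)(=O)c1ccc(Cc2n[nH]c(=S)n2/N=C/c2ccc(-c3ccccc3)cc2)cc1` differs from compound 1 by phenyl in place of methylsulfanyl on an aromatic carbon. The measured steps change the group on the carbon with a double bond to nitrogen, not the aromatic carbon concerned here: an at least 2.0-fold higher number from compound 1 to compound 2 (0.30 log units; that floor lies within the scatter) is capped by the limit of > 100000 nM in this assay, at which 1 of the 3 values shown sits, and a 2.0-fold higher number from compound 1 to compound 3 (0.30 log units; within the scatter) is small. Among the measured compounds shown here, no step bears directly on the change, so compound 4 is expected to stay close to compound 1, with a 1.2-fold higher number from compound 1 to compound 4 (0.08 log units; within the scatter). For compound 4 the estimate in this assay is 60000 nM, between 20000 nM and 150000 nM.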

Compound 4, half-maximal effective concentration: 50000 nM
The estimate for compound 4 lay 1.2-fold (0.08 log units) above the measured number; low and high end bracket the measured number.
By their numbers in this assay, from the lowest: compounds 1, 4 and 3 (each within the scatter of the next).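

In this assay, phenyl in place of methylsulfanyl gives no change at the digits printed from compound 1 to compound 4 (within the scatter). The earlier steps shown here exchanged the whole group on the carbon with a double bond to nitrogen, whereas this one shows that the aromatic carbon para to a large group can carry a six-membered aromatic ring of carbon only with no readable difference from methylsulfanyl. Nothing measured here accounts for this outcome. On these data alone, whether an amine or a carboxylic acid on this aromatic carbon would read the same remains open.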